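Methoxy for Methyl on the Outer Ring of Compound 1

This account rests on a few compounds, and the source may have more. Where it says the series, first, only, none or still open, it means among the compounds named here.

compound 1 `Cc1ccccc1-c1cccc(COc2ccc([C@H](CC(=O)O)c3nccn3C)cc2)c1` — 43 nM
compound 2 `CCc1ccccc1-c1cccc(COc2ccc([C@H](CC(=O)O)c3nccn3C)cc2)c1` — 48 nM
compound 3 `Cc1c(Cl)cccc1-c1cccc(COc2ccc([C@H](CC(=O)O)c3nccn3C)cc2)c1` — 61 nM

Three compounds share one core and differ only in the substituents on the outer phenyl ring. In an assay on CHO cells for agonist activity at Free fatty acid receptor 1 (Homo sapiens), read by luminescence, with a stated time of 20 s, in the presence of a further agent that is not named here (on this read-out lower numbers stand for an effect already at smaller amounts and higher numbers for an effect only at larger amounts of compound), compound 1 gives 43 nM, the lowest of the three numbers, but both of its steps stay within the scatter: a 1.1-fold higher number from compound 1 to compound 2 (0.05 log units; within the scatter) and a 1.4-fold higher number from compound 1 to compound 3 (0.15 log units; within the scatter). Between the other two the step is a 1.3-fold higher number from compound 2 to compound 3 (0.10 log units; within the scatter). None of the three can therefore be set apart from the others.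

Compound 4 `COc1ccccc1-c1cccc(COc2ccc([C@H](CC(=O)O)c3nccn3C)cc2)c1` is reached from compound 1 by methoxy in place of methyl on an aromatic carbon. The measured steps that bear on this change are the two other alterations of the same outer ring, a 1.1-fold higher number from compound 1 to compound 2 (0.05 log units; within the scatter) and a 1.4-fold higher number from compound 1 to compound 3 (0.15 log units; within the scatter), both within the scatter. Neither of them introduced a hydrogen-bond acceptor as the methoxy group does, so the change is not covered exactly, and the three measured compounds give no ground for a step beyond the scatter in either direction.

Compound 4 is therefore expected to give 55 nM in this assay, within a range from 25 nM to 130 nM. The expected step is a 1.3-fold higher number from compound 1 to compound 4 (0.11 log units; within the scatter), and this estimate places it within the scatter.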

Compound 4, half-maximal effective concentration: 410 nM
Beside the measured number, compound 4's estimate is 7.5-fold (0.87 log units) below it, and the stated range ends below it.
By their numbers in this assay, from the lowest: compounds 1, 2 and 3 (each within the scatter of the next); then compound 4.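

In this assay, this place on the outer ring, ortho to a large group, proves sensitive to the group it carries: methoxy in place of methyl gives a 9.5-fold higher number from compound 1 to compound 4 (0.98 log units; beyond the scatter), whereas the earlier changes to the same ring stayed within the scatter. Among these compounds, the step holds against the other two compounds as well, with an 8.5-fold higher number from compound 2 to compound 4 (0.93 log units; beyond the scatter) and a 6.7-fold higher number from compound 3 to compound 4 (0.83 log units; beyond the scatter), so compound 4 stands apart from all three, and the ethyl of compound 2 at the same place gives no such step. The change brings in one oxygen and one hydrogen-bond acceptor, but nothing available here shows why the number rises.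

The compounds shown leave open whether the step goes with the oxygen itself or with the particular group, a question that hydroxy, ethoxy or an amine at the same carbon would address. They also leave open whether methoxy would give a similar step at another carbon of the outer ring, or whether a chloro on the ring of compound 4 would change its number.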